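Aryl swap on the exocyclic alkene of the shared core

The source may report more compounds than this note shows. Statements on the series, on what has been measured and on what is new or still open speak of the compounds shown alone.

Compound 1 `CN(C)c1ccc(C=C2C(=O)N(c3ccc(Cl)cc3)N(c3ccc(Cl)cc3)C2=O)cc1` is the reference point of this set. In a functional assay on SMMC-7721 cells (Homo sapiens) for cytotoxicity, read by MTT assay, with a stated time of 72 h (a higher number here means a weaker inhibitor, a lower number a stronger inhibitor), compound 1 gives only a limit of the assay, > 128000 nM, and no number. The two measured neighbours carry a different aryl group on the exocyclic carbon: compound 2 `O=C1C(=Cc2cccc(Cl)c2)C(=O)N(c2ccc(Cl)cc2)N1c1ccc(Cl)cc1` gives 20200 nM and compound 3 `COc1cccc(C=C2C(=O)N(c3ccc(Cl)cc3)N(c3ccc(Cl)cc3)C2=O)c1OC` gives 14100 nM. The steps are an at least 6.3-fold lower number from compound 1 to compound 2 (0.80 log units; beyond the scatter) and an at least 9.0-fold lower number from compound 1 to compound 3 (0.95 log units; beyond the scatter), both beyond the scatter, and a 1.4-fold lower number from compound 2 to compound 3 (0.16 log units; within the scatter) lies within it, so compounds 2 and 3 cannot be ordered against each other; the size of the first two steps is bounded only from below because of the limit of > 128000 nM in this assay, at which 1 of the 3 values shown sits.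

Compound 4 `O=C1C(=Cc2ccc(F)cc2F)C(=O)N(c2ccc(Cl)cc2)N1c1ccc(Cl)cc1` makes the same kind of change at the same place: 2,4-difluorophenyl in place of 4-(dimethylamino)phenyl on a double-bonded chain carbon bound to a double-bonded ring carbon. The bearing steps are those to compounds 2 and 3, each at least modest and downward in number. A step of similar direction and size is therefore expected here, with no measured basis for telling a halogenated aryl from a methoxylated one.

Compound 4 is estimated at 20000 nM, within 6000 nM to 70000 nM, which would mean an expected step of an at least 6.4-fold lower number from compound 1 to compound 4 (0.80 log units; beyond the scatter).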

Compound 4, half-maximal inhibitory concentration: 35800 nM
Compound 4: middle estimate off by 1.8-fold (0.25 log units), on the low side, and the stated range covers the measured number.
By their numbers in this assay, from the lowest: compounds 3, 2 and 4 (each within the scatter of the next, the first and the last beyond it). At a limit, above all of these: compound 1.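

In this assay, 2,4-difluorophenyl on a double-bonded chain carbon bound to a double-bonded ring carbon joins the other two replacements for 4-(dimethylamino)phenyl in giving a measurable number, with an at least 3.5-fold lower number from compound 1 to compound 4 (0.55 log units; beyond the scatter). Compound 1 stands at a limit, so that step is a lower bound only: the limit of > 128000 nM in this assay, at which 1 of the 4 values shown sits. Among the compounds shown here, what is new is the first separation among the measurable aryl groups, with a 2.5-fold higher number from compound 3 to compound 4 (0.40 log units; beyond the scatter) beyond the scatter, while a 1.8-fold higher number from compound 2 to compound 4 (0.25 log units; within the scatter) stays within it, so this place does distinguish 2,4-difluorophenyl from 2,3-dimethoxyphenyl, but only modestly, and no clean split of halogenated against methoxylated aryl groups follows, as compound 2 cannot be separated from either compound 3 or compound 4.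

Going by these compounds, it remains open whether the limit of compound 1 follows the dimethylamino group itself or any 4-substituted phenyl, which a 4-methoxyphenyl or 4-aminophenyl group at this place would help to decide. Also open is how this place responds to a group outside the neutral substituted phenyls shown, such as a carboxylic acid on the phenyl ring or a pyridine in its stead.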